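Lengthening the Chain Once More: An Estimate for Compound 4

A few compounds are considered here, and "the series" means these few. Any claim that something is new, unique, unknown or untested is made for them only; others in the source may bear on it.

In a functional assay on NCI-H630 cells (Homo sapiens) for cytotoxicity, read by sulforhodamine B assay, with a stated time of 5 days (a higher number here means a weaker inhibitor, a lower number a stronger inhibitor), compound 1 `O=C(CCCCCCCc1ccccc1)N[C@H]1CCOC1=O` gives > 100000 nM, and this is a limit of the assay and not a number. Two close relatives give true numbers. In this assay compound 2 `O=C(CCCCc1ccccc1)CC(=O)N[C@H]1CCOC1=O` gives 80000 nM, while compound 3 `O=C(CCCCCc1ccccc1)CC(=O)N[C@H]1CCOC1=O` gives 24000 nM, the lower of these two numbers.

The next compound to be measured is compound 4 `O=C(CCCCCCc1ccccc1)CC(=O)N[C@H]1CCOC1=O`. Its difference from compound 3 is benzyl in place of phenyl on a saturated chain carbon, five bonds along the chain from a carbonyl carbon. In words, this is benzyl in place of phenyl on a saturated chain carbon, five bonds along the chain from a carbonyl carbon.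

For the measured compounds named here, only one measured step bears on this change. It is the same exchange of phenyl for benzyl, made four bonds along the chain from a carbonyl carbon: a 3.3-fold lower number from compound 2 to compound 3 (0.52 log units; beyond the scatter). This modest step is beyond the usual scatter, but a single step is thin support, and the trend may not continue. Going by the values given here, compound 1 adds no step, since it offers only a limit.

The expected change is a 2.4-fold lower number from compound 3 to compound 4 (0.38 log units; beyond the scatter), a modest move towards a lower number. For compound 4 the estimated value is 10000 nM, with an expected range from 3000 nM to 30000 nM.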

Compound 4, half-maximal inhibitory concentration: 27000 nM
Compound 4: the middle estimate sits 2.7-fold (0.43 log units) below what was measured; low and high end bracket the measured number.
By their numbers in this assay, from the lowest: compounds 3 and 4 (each within the scatter of the next); then compound 2. At a limit, above all of these: compound 1.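

At the position five bonds along the chain from a carbonyl carbon, benzyl in place of phenyl gives a 1.1-fold higher number from compound 3 to compound 4 (0.05 log units; within the scatter) in this assay, so the two compounds cannot be told apart here, although the same exchange four bonds along gave a 3.3-fold lower number from compound 2 to compound 3 (0.52 log units; beyond the scatter). The lengthening that paid off once therefore does not form a steady trend across this short series, and the second exchange is the one that goes against any such trend. The longer change, phenethyl in place of phenyl at the position four bonds along the chain from a carbonyl carbon, still gives a 3.0-fold lower number from compound 2 to compound 4 (0.47 log units; beyond the scatter), so the lower number reached with the first exchange is kept and not lost; no measurement shown bears on why the numbers level off at this chain length.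

On these data alone, whether a longer chain would hold this level or raise the number again remains open. So does the effect of a carboxylic acid or an amine on the phenyl ring, and whether the same levelling would appear in cells other than those of this assay.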